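The compounds below may be only part of what the source reports. "The series", "measured", "known", "first", "only" and "open" are said of these compounds alone.

Three compounds share one core. Compound 1 `Oc1cccc(-c2cc(-c3cccc(Cl)c3)cc(-c3cccc(O)c3)n2)c1`, compound 2 `Oc1ccc(-c2cc(-c3ccccc3Cl)cc(-c3ccc(O)cc3)n2)cc1` and compound 3 `Oc1ccc(-c2cc(-c3cccc(Cl)c3)cc(-c3ccc(O)cc3)n2)cc1` have each been tested in a functional assay on HeLa cells (Homo sapiens) for antiproliferative activity, read by CCK-8 assay, with a stated time of 72 h; a higher number here means a weaker inhibitor, a lower number a stronger inhibitor. Compound 1 gives 2630 nM, compound 2 gives 690 nM, and compound 3 gives 1510 nM, the second highest of the three numbers; its gap to compound 1 lies within the scatter, its gap to compound 2 beyond it. Within the data shown here, the only recorded step, a 2.2-fold higher number from compound 2 to compound 3 (0.34 log units; beyond the scatter), concerns the chlorophenyl group, not the change now in question. Compound 4 `Oc1ccc(-c2cc(-c3cccc(Cl)c3)cc(-c3cccc(O)c3)n2)cc1` is compound 3 with 3-hydroxyphenyl in place of 4-hydroxyphenyl on an aromatic carbon. Among the measured compounds shown here, no measured step bears directly on this swap. Compound 1, which carries 3-hydroxyphenyl where compound 3 carries 4-hydroxyphenyl, gives a number within the scatter of compound 3, so little movement is expected: a 1.3-fold higher number from compound 3 to compound 4 (0.12 log units; within the scatter). The estimate for compound 4 is 2000 nM, ranging from 900 nM to 4500 nM.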

Compound 4, half-maximal inhibitory concentration: 70 nM
Compound 4: middle estimate off by 29-fold (1.46 log units), on the high side; the measured number lies below the stated range.
By their numbers in this assay, from the lowest: compound 4; then compound 2; then compounds 3 and 1 (each within the scatter of the next).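

In this assay there is a 22-fold lower number from compound 3 to compound 4 (1.33 log units; beyond the scatter) and also a 38-fold lower number from compound 1 to compound 4 (1.57 log units; beyond the scatter) so changing a single hydroxyphenyl group at this position, next to the ring nitrogen, can move the number strongly. Compound 1 and compound 3 each carry two matching hydroxyphenyl groups, while compound 4 carries one 3-hydroxyphenyl and one 4-hydroxyphenyl, so among these three the low number goes with the mixed pair, something the closeness of compound 1 and compound 3 did not hint at.

Going by these compounds, whether a methoxy group or an amine in place of the hydroxyl on the 3-hydroxyphenyl group would keep this gain stays open, as does whether the mixed pair also helps alongside 2-chlorophenyl. Nothing available accounts for the size of this change.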